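Trimethylphenyl in place of fluorobenzyl on the shared core

The source may report more compounds than this note shows. Statements on the series, on what has been measured and on what is new or still open speak of the compounds shown alone.

Of the compounds shown here, three of one series have been measured in a functional assay on MDA-MB-231 cells (Homo sapiens) for inhibition, read by CCK-8 assay, with a stated time of 48 h; a lower number here means a stronger inhibitor of growth, a higher number a weaker inhibitor of growth. Compound 1, `Cc1ccccc1Nc1nc(Nc2ccc(N3CCCCC3)cn2)ncc1Cl`, reaches only the limit of the assay, > 100000 nM, and no number is known for it. Compound 2, `Cc1ccccc1Nc1nc(Nc2ccc(N3CCN(C)CC3)cc2)ncc1Cl`, gives 7020 nM in this assay. Compound 3, `CN1CCN(c2ccc(Nc3ncc(Cl)c(NCc4ccc(F)cc4)n3)nc2)CC1`, also returns only a limit, > 100000 nM, and so no number is known for it either. Compound 3 therefore stands at the weak end of the values shown, at the limit of > 100000 nM in this assay, at which 2 of the 3 values shown sit, and how far beyond that limit it lies cannot be told.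

Compound 4, `Cc1cc(C)c(Nc2nc(Nc3ccc(N4CCN(C)CC4)cn3)ncc2Cl)c(C)c1`, has not yet been measured. It differs from compound 3 in one place: 2,4,6-trimethylphenyl in place of 4-fluorobenzyl on a nitrogen on an aromatic ring. Within the data shown here, no step between measured compounds is available to gauge this change directly. Among the measured compounds shown here, the only number in the set belongs to compound 2, which gives 7020 nM in this assay. Compound 1 and compound 3 return no number.

From compound 3 to compound 4 an improvement is expected, an at least 5.0-fold lower number from compound 3 to compound 4 (0.69 log units; beyond the scatter), though its size is uncertain because compound 3 sits at > 100000 nM. Compound 4 is therefore estimated at 20000 nM, with a range from 3000 nM to 100000 nM, and a limit rather than a number remains possible.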

Compound 4, concentration for 50% growth inhibition: 21000 nM
Compound 4: middle estimate off by 1.1-fold (0.02 log units), on the low side; the measured number falls inside the stated range.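

Among these compounds, at this position, on a nitrogen on an aromatic ring, the change from 4-fluorobenzyl to 2,4,6-trimethylphenyl gives the first readable step in this assay, which is an at least 4.7-fold lower number from compound 3 to compound 4 (0.67 log units; beyond the scatter). Both groups hold one six-membered aromatic ring of carbon only, so the presence of such a ring alone does not settle the outcome here, and compound 4 returns a number where compound 3 did not. The step is only a bound and its full size cannot be told, because compound 3 stands at a limit of the assay: the limit of > 100000 nM in this assay, at which 2 of the 4 values shown sit.

The compounds shown do not separate the parts of this change, since the benzyl carbon and the fluorine leave while three methyl groups enter in a single step, and a plain phenyl or a 4-fluorophenyl on the same nitrogen would be needed to tell these parts apart. Also open, going by these compounds, is how an amine or a carboxylic acid on that aromatic ring would behave, and whether the number can be brought lower at this position at all.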